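This account rests on a few compounds, and the source may have more. Where it says the series, first, only, none or still open, it means among the compounds named here.

Compound 1 `C=CC(=O)Nc1cc2c(Nc3ccc(OCc4cccc(F)c4)c(Cl)c3)ncnc2cc1OCc1cn(CCCC(=O)NO)nn1`: 20200 nM
Compound 2 `C=CC(=O)Nc1cc2c(Nc3ccc(OCc4cccc(F)c4)c(Cl)c3)ncnc2cc1OCc1cn(CCCCC(=O)NO)nn1`: 16000 nM
Compound 3 `CN(C)C/C=C/C(=O)Nc1cc2ncnc(Nc3ccc(F)c(Cl)c3)c2cc1O[C@@H]1CCOC1`: 5560 nM

In a functional assay on SK-BR-3 cells (Homo sapiens) for antiproliferative activity, read by MTT assay, with a stated time of 72 h (on this read-out higher numbers stand for weaker inhibition and lower numbers for stronger inhibition), compound 2 gives 16000 nM, within the scatter of compound 1 and higher than compound 3. Compound 4 `C=CC(=O)Nc1cc2c(Nc3ccc(F)c(Cl)c3)ncnc2cc1OCc1cn(CCCCC(=O)NO)nn1` departs from compound 2 in one place: fluoro in place of (3-fluorobenzyl)oxy on an aromatic carbon. For the measured compounds named here, the only measured step, a 1.3-fold lower number from compound 1 to compound 2 (0.10 log units; within the scatter), lies within the scatter and concerns the chain, so no measured step bears directly on this change. Compound 3 also carries fluoro on that ring, and its value of 5560 nM offers a weak hint towards a lower number. A moderate fall in this assay is therefore expected, though it may not clear the scatter. The step expected is a 2.0-fold lower number from compound 2 to compound 4 (0.30 log units; within the scatter). Compound 4 is estimated at 8000 nM, within an expected range of 2500 nM to 20000 nM.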

Compound 4, half-maximal inhibitory concentration: 20000 nM
Compound 4: the middle estimate sits 2.5-fold (0.40 log units) below what was measured, and the stated range covers the measured number.
By their numbers in this assay, from the lowest: compound 3; then compounds 2, 4 and 1 (each within the scatter of the next).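

In this assay the exchange of (3-fluorobenzyl)oxy for fluoro on the aromatic carbon ortho to a chloro group gives a 1.3-fold higher number from compound 2 to compound 4 (0.10 log units; within the scatter) and so shows that this position tolerates the loss of the whole group, ring included, with no change beyond the scatter. Nothing measured here explains this outcome.

The compounds shown leave open whether a methoxy group or an amine on this carbon would shift the number beyond the scatter. They also leave open whether the same exchange would read alike on a longer chain.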